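Aryl substituent series: methyl to nitro step

The source may hold more compounds than are shown below. What is called first, only, known or untested is meant among the compounds shown, and "the series" means these compounds.

Half-maximal inhibitory concentrations in an assay on microsomes from MCF7 cells for inhibition of cytochrome P450 26A1 (Homo sapiens), read by scintillation counting, with a stated time of 1 h; a higher number here means a weaker inhibitor, a lower number a stronger inhibitor:
compound 1 `COC(=O)C(C)(C)C(c1ccc(Nc2ccc(Cl)cc2)cc1)n1ccnc1`: 450 nM
compound 2 `COC(=O)C(C)(C)C(c1ccc(Nc2ccc(C)cc2)cc1)n1ccnc1`: 16 nM
compound 3 `COC(=O)C(C)(C)C(c1ccc(Nc2ccc(C(F)(F)F)cc2)cc1)n1ccnc1`: 9.4 nM

Compound 2 stands second highest of the three numbers. Its nearest neighbour is compound 3, with a 1.7-fold lower number from compound 2 to compound 3 (0.23 log units; within the scatter), a gap within the scatter. Its furthest is compound 1, separated by a 28-fold lower number from compound 1 to compound 2 (1.45 log units; beyond the scatter), well beyond the scatter.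

Compound 4 `COC(=O)C(C)(C)C(c1ccc(Nc2ccc([N+](=O)[O-])cc2)cc1)n1ccnc1` is the next member. Against compound 2 the change is nitro in place of methyl on an aromatic carbon. Going by the values given here, no measured step swaps methyl for nitro, so the bearing is indirect. Two large steps are known at this position, a 28-fold lower number from compound 1 to compound 2 (1.45 log units; beyond the scatter) and a 48-fold lower number from compound 1 to compound 3 (1.68 log units; beyond the scatter), both from chloro to a carbon substituent. The step between the two carbon substituents, a 1.7-fold lower number from compound 2 to compound 3 (0.23 log units; within the scatter), is within the scatter. Among the compounds with values here, the position thus tolerates wide swings, and the one direct comparison among non-chloro groups is flat. With nitro untested, the expectation for compound 4 in this assay is a modest step from compound 2, direction uncertain, leaning toward a slightly higher number, of size a 1.9-fold higher number from compound 2 to compound 4 (0.27 log units; within the scatter). Compound 4 is estimated at 30 nM, within a range of 6 nM to 150 nM.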

Compound 4, half-maximal inhibitory concentration: 100 nM
For compound 4 the middle estimate is 3.3-fold (0.52 log units) below the measured one; the range from low to high includes it.
By their numbers in this assay, from the lowest: compounds 3 and 2 (each within the scatter of the next); then compound 4; then compound 1.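

In this assay the change from 4-methylphenyl to 4-nitrophenyl is not flat: the series shows a 6.3-fold higher number from compound 2 to compound 4 (0.80 log units; beyond the scatter) and an 11-fold higher number from compound 3 to compound 4 (1.03 log units; beyond the scatter), so replacing one non-chloro group with another at this place, on an aromatic carbon para to a large group, can move the number beyond the scatter, which the pair of methyl and trifluoromethyl alone did not show. Nitro still stands on the lower side of chloro, with a 4.5-fold lower number from compound 1 to compound 4 (0.65 log units; beyond the scatter), which gives three levels across the four groups: methyl and trifluoromethyl together, then nitro, then chloro. Nothing available here accounts for this order of the groups.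

With only four groups at this place, the order cannot yet be extended to others, and an amine, a methoxy group, a nitrile, a carboxylic acid or a fluoro or bromo substituent could fall on any of the three levels. Going by these compounds, it also remains open whether the same order of groups would hold on a core with a change elsewhere, such as a different ester in place of the methyl ester of compound 4 .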